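This account rests on a few compounds, and the source may have more. Where it says the series, first, only, none or still open, it means among the compounds named here.

Compound 2 `C=CCn1ncc2c(Br)nc(Cc3ccccc3)n2c1=O` is the point of departure for this account. In a functional assay for inhibition, with Homo sapiens as the target (on this read-out lower numbers stand for stronger inhibition and higher numbers for weaker inhibition), compound 2 gives > 48000 nM, which is a limit of the assay rather than a number. Compound 1 `C=CCn1ncc2cnc(Cc3ccccc3)n2c1=O` differs from compound 2 only by hydrogen in place of the bromo on an aromatic carbon. In this assay compound 1 gives > 48000 nM, again a limit. The step that the two limits leave unreadable from compound 1 to compound 2 therefore stays unreadable. Compound 3 `CCCc1ncn2c(Nc3cc[nH]n3)nccc12` stands apart from both in structure. In this assay compound 3 gives > 48000 nM, also a limit. What the measured numbers show is summed up by the limit of > 48000 nM in this assay, at which 3 of the 3 values shown sit. Compound 4 `C=CCn1ncc2c(Br)nc(CCC)n2c1=O` has not yet been measured; it differs from compound 2 by ethyl in place of phenyl on a saturated chain carbon bound to an aromatic carbon. Going by the values given here, no measured step bears on this change, and the one step that exists cannot be sized. The expected step that the limit leaves unreadable from compound 2 to compound 4 is thus none that can be told beyond the scatter. The estimate for compound 4 in this assay is accordingly 60000 nM, with a range from 20000 nM to 200000 nM, and it is expected most likely to be reported again only as a limit.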

Compound 4, half-maximal inhibitory concentration: > 48000 nM
Compound 4: no number, only a limit; the forecaster's own chance of this, stated with the estimate: 85%; the middle value is on the limit's open side.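

In this assay compound 4, like compound 2, gives only a limit, so no step can be read from compound 2 to compound 4. The compounds shown leave open which change, if any, would bring a readable number, and all of them sit at one value: the limit of > 48000 nM in this assay, at which 4 of the 4 values shown sit.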